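A 2,4-dichlorophenyl swap on compound 3

The compounds below may be only part of what the source reports. "The series", "measured", "known", "first", "only" and "open" are said of these compounds alone.

Within the data shown here, in a functional assay on K562 cells (Homo sapiens) for cytotoxicity, read by MTT assay, with a stated time of 24 h (a lower number here means a stronger inhibitor, a higher number a weaker inhibitor), compound 3 `CN1C/C(=C\c2ccc(F)cc2)C(=O)/C(=C/c2cccc([N+](=O)[O-])c2)C1` gives 11300 nM, the higher of the two numbers measured so far. Compound 1 `COc1cc(/C=C2\CN(C)C/C(=C\c3ccccc3F)C2=O)cc(OC)c1OC` gives 4340 nM, lower by a margin beyond the scatter. Compound 2 `COc1cc(/C=C2\CN(C)C/C(=C\c3ccc(Cl)cc3)C2=O)cc(OC)c1OC` gives > 20000 nM, which is a limit of the assay and not a number.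

Compound 4 `CN1C/C(=C\c2cccc([N+](=O)[O-])c2)C(=O)/C(=C/c2ccc(Cl)cc2Cl)C1` differs from compound 3 in one place, on a double-bonded chain carbon bound to a double-bonded ring carbon, where 2,4-dichlorophenyl stands in place of 4-fluorophenyl: 2,4-dichlorophenyl in place of 4-fluorophenyl on a double-bonded chain carbon bound to a double-bonded ring carbon.

Among the measured compounds shown here, only one measured step bears on this change: an at least 4.6-fold higher number from compound 1 to compound 2 (0.66 log units; beyond the scatter). In that step, 4-chlorophenyl replaced 2-fluorophenyl on the same kind of chain carbon. Its size is only a bound, set by the limit of > 20000 nM in this assay, at which 1 of the 3 values shown sits. It was also measured with a different group on the other side of the shared core, so it carries over only loosely. Neither the leaving nor the entering group of the present change has been measured directly. A modest move towards a higher number is therefore expected in this assay, and a limit reading remains possible. The expected change is a 1.4-fold higher number from compound 3 to compound 4 (0.15 log units; within the scatter). For compound 4 the estimated value is 16000 nM, with an expected range from 6000 nM to 40000 nM.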

Compound 4, half-maximal inhibitory concentration: 12400 nM
Estimate against measurement, compound 4: 1.3-fold (0.11 log units) above, and the stated range covers the measured number.
By their numbers in this assay, from the lowest: compound 1; then compounds 3 and 4 (each within the scatter of the next). At a limit, above all of these: compound 2.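

In this assay, the swap at this position gives a 1.1-fold higher number from compound 3 to compound 4 (0.04 log units; within the scatter), so the two compounds cannot be told apart here. Among these compounds, this is the first step at this kind of chain carbon with a number at both ends, and it was read with the group on the other side of the shared core held the same. The only earlier step of this kind, an at least 4.6-fold higher number from compound 1 to compound 2 (0.66 log units; beyond the scatter), gave just a bound, its end point being a limit: the limit of > 20000 nM in this assay, at which 1 of the 4 values shown sits.

The new pair therefore shows that, with the other side fixed, exchanging 4-fluorophenyl for 2,4-dichlorophenyl does not move the reading beyond the scatter, though this rests on one pair alone.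

The compounds shown leave open whether the same exchange would read alike with the trimethoxy-substituted phenyl of compound 1 on the other side of the core. They also leave open how this position responds to groups of another kind, such as a phenyl ring carrying an amine or a carboxylic acid, or a longer chain ending in a hydroxyl group.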